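The source may report more compounds than this note shows. Statements on the series, on what has been measured and on what is new or still open speak of the compounds shown alone.

Cytotoxicity notes, series measured in an ADME assay on L929 cells (Mus musculus) for cytotoxicity, read by resazurin assay, with a stated time of 72 h; a lower number here means a stronger inhibitor, a higher number a weaker inhibitor:
compound 1 `OB1OCc2ccc(-n3cccc3)cc21`: > 10 ug/mL
compound 2 `O=C(O)c1cccn1-c1ccc2c(c1)B(O)OC2`: > 10 ug/mL
compound 3 `CCNC(=O)c1cccn1-c1ccc2c(c1)B(O)OC2`: > 10 ug/mL

Compound 1 gives only a limit of the assay, not a number. The same holds for compound 2 and for compound 3, so compound 3 stands at the limit with the other two and the three cannot be ordered. The steps a step that the two limits leave unreadable from compound 1 to compound 2, a step that the two limits leave unreadable from compound 1 to compound 3 and a step that the two limits leave unreadable from compound 2 to compound 3 are unreadable on that account, resting on (the limit of > 10 ug/mL in this assay, at which 3 of the 3 values shown sit). Compound 4 `CC(=O)c1cccn1-c1ccc2c(c1)B(O)OC2` differs from compound 3 by methyl in place of ethylamino on a carbonyl carbon. Among the compounds with values here, no measured step gives a readable size for this change; what is known is only that compound 3 sits at the limit. The step from compound 3 to compound 4 in this assay is expected to be a step that the limit leaves unreadable from compound 3 to compound 4, nothing beyond the scatter. For compound 4 the expected value in this assay is 20 ug/mL, with a range from 8 ug/mL to 60 ug/mL, most likely again reported only as a limit.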

Compound 4, half-maximal inhibitory concentration: > 10 ug/mL
Compound 4 was reported as a limit (the forecaster's own chance of this, stated with the estimate: 80%); the middle value does not contradict the limit.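

Compound 4, like compound 1, compound 2 and compound 3, gives only a limit in this assay, so no new step can be read: the limit of > 10 ug/mL in this assay, at which 4 of the 4 values shown sit.

The compounds shown leave open how the four would order in this assay if any gave a number.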